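Amide change on a pyrimidine amide scaffold

The source may report more compounds than this note shows. Statements on the series, on what has been measured and on what is new or still open speak of the compounds shown alone.

Compound 1 `CN(CCCn1ccnc1)C(=O)[C@@H]1CCCN1c1nccc(Nc2ccccc2)n1` gives 0% in an assay on isolated protein for inhibition of Ephrin type-B receptor 4 (Homo sapiens), read by HTRF, tested at 10 uM; a lower number here means less inhibition, a higher number more inhibition at the concentration tested (going by the name of the read-out). Compound 2 `Cc1cccc(Oc2ccnc(N3CCN(C(=O)c4c(C)noc4C)CC3)n2)c1` gives 0% in this assay, so compound 1 stands level with compound 2 within the scatter. Compound 3 `COC[C@@H]1CCCN1C(=O)[C@@H]1CCCN1c1nccc(Nc2ccccc2)n1` differs from compound 1 by 2-(methoxymethyl)pyrrolidin-1-yl in place of (3-(1H-imidazol-1-yl)propyl)(methyl)amino on a carbonyl carbon. For the measured compounds named here, no measured pair shows the effect of such a change, and both measured compounds sit at the bottom of the scale, so the step from compound 1 to compound 3 is expected to stay within the scatter in this assay, as no change at the digits printed from compound 1 to compound 3 (within the scatter). Compound 3 is therefore estimated at 0%, between -8% and 10%.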

Compound 3, a percentage reported as inhibition, at one concentration (the size of the read-out at that concentration, not a potency): 0%
Compound 3: middle estimate and measured number agree at the digits printed, and the stated range covers the measured number.
By their numbers in this assay, from the lowest: compounds 1, 2 and 3 (each within the scatter of the next).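

On the carbonyl carbon, 2-(methoxymethyl)pyrrolidin-1-yl in place of (3-(1H-imidazol-1-yl)propyl)(methyl)amino gives no change at the digits printed from compound 1 to compound 3 (within the scatter) in this assay, the only step shown at this position. With compound 1 at 0%, this step cannot tell whether either group contributes anything to inhibition. Nothing measured bears on why the read-out stays the same. Going by these compounds, it remains open whether another group on this carbonyl carbon, such as a primary amine or a longer chain ending in a carboxylic acid, would give measurable inhibition. On these data alone, the effect of changes elsewhere on the core of compound 1 also remains open.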